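Sulfonamide aryl swap from compound 2 to compound 3

This account rests on a few compounds, and the source may have more. Where it says the series, first, only, none or still open, it means among the compounds named here.

In a functional assay on DU-145 cells (Homo sapiens) for antiproliferative activity, read by MTT assay, with a stated time of 72 h (on this read-out lower numbers stand for stronger inhibition and higher numbers for weaker inhibition), compound 1 `CCN(c1ccc(OC)cc1)S(=O)(=O)C1CC2OC1C(c1ccc(NC(=O)CCCCCCC(=O)O)cc1)=C2c1ccc(O)cc1` gives 24400 nM and compound 2 `CCN(c1cccc(OC)c1)S(=O)(=O)C1CC2OC1C(c1ccc(NC(=O)CCCCCCC(=O)O)cc1)=C2c1ccc(O)cc1` gives 71100 nM as the higher of the two numbers, making compound 2 the weaker inhibitor of the pair. Compound 3 `CCN(c1ccccc1Br)S(=O)(=O)C1CC2OC1C(c1ccc(NC(=O)CCCCCCC(=O)O)cc1)=C2c1ccc(O)cc1` carries 2-bromophenyl in place of 3-methoxyphenyl on a sulfonamide nitrogen with the rest of the structure unchanged. For the measured compounds named here, the only measured step that bears on this is a 2.9-fold higher number from compound 1 to compound 2 (0.46 log units; beyond the scatter) for 3-methoxyphenyl in place of 4-methoxyphenyl on that nitrogen, modest but beyond the scatter. Going by the values given here, no bromine-bearing compound has been measured, so direction and size remain poorly fixed. Among the compounds with values here, with compound 2 at 71100 nM as the higher of only two numbers, a move toward a lower number is expected. An estimated 1.7-fold lower number from compound 2 to compound 3 (0.23 log units; within the scatter) is expected, a small step that may stay within the scatter. In this assay compound 3 is estimated at 42000 nM (expected range 15000 nM to 110000 nM).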

Compound 3, half-maximal inhibitory concentration: 95300 nM
Beside the measured number, compound 3's estimate is 2.3-fold (0.36 log units) below it; low and high end bracket the measured number.
By their numbers in this assay, from the lowest: compound 1; then compounds 2 and 3 (each within the scatter of the next).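

In this assay the exchange at the sulfonamide nitrogen gives a 1.3-fold higher number from compound 2 to compound 3 (0.13 log units; within the scatter) and so does not separate 2-bromophenyl from 3-methoxyphenyl, although the two groups differ in ring substituent. The second new comparison, a 3.9-fold higher number from compound 1 to compound 3 (0.59 log units; beyond the scatter) for 2-bromophenyl in place of 4-methoxyphenyl, adds a further aryl group that stands apart from 4-methoxyphenyl, which leaves compound 1 as the strongest inhibitor of these three. No measured evidence bears on why these aryl groups compare this way.

Still open, on these data alone, is whether the lower number in compound 1 belongs to the methoxy group itself or would also hold for another group, such as 4-bromophenyl or 4-aminophenyl, on this nitrogen. The compounds shown also leave open how a longer chain, such as propyl in place of ethyl on the same nitrogen, would read in this series.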